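Methoxy to Nitro: Cytotoxicity Notes on the Series

A few compounds are considered here, and "the series" means these few. Any claim that something is new, unique, unknown or untested is made for them only; others in the source may bear on it.

Compound 1 `O=C1CSC(c2cccc(Cl)c2)N1CCN1CCCCC1` and compound 2 `COc1ccccc1C1SCC(=O)N1CCN1CCCCC1` share one core and differ only in the group carried on the aromatic ring. In an ADME assay on Vero cells (Chlorocebus sabaeus) for cytotoxicity, read by neutral red uptake, tested at 98 ug/mL (a higher number here means a weaker effect of the compound at the concentration tested, a lower number a stronger effect), compound 1 gives 100%. In this assay compound 2 gives 100%, level with compound 1 at the digits shown; the two readings sit within the scatter of each other, so no order or change can be read from this pair. Both values lie at the top of the scale, meaning neither compound showed a measurable effect on the cells at the tested concentration.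

Compound 3 `O=C1CSC(c2ccccc2[N+](=O)[O-])N1CCN1CCCCC1` has not yet been measured. Against compound 2 the change is nitro in place of methoxy on an aromatic carbon. Within the data shown here, no quantified step between measured compounds exists, so the size of a nitro-for-methoxy effect in this assay is unknown; given that compound 1 and compound 2 carry different ring groups yet both read at the ceiling, a step of no more than the scatter is expected, in no particular direction. The step from compound 2 to compound 3 is estimated as a number 2 percentage points lower from compound 2 to compound 3 (within the scatter). Compound 3 is therefore expected to give 98% in this assay, within a range of 85% to 100%.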

Compound 3, a percentage reported as activity, at one concentration (the size of the read-out at that concentration, not a potency): 100%
The estimate for compound 3 lay 2 percentage points below the measured number, within the range that was stated.
By their numbers in this assay, from the lowest: compounds 1, 2 and 3 (each within the scatter of the next).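

Nitro in place of methoxy on an aromatic carbon, ortho to a large group, gives no change at the digits printed from compound 2 to compound 3 (within the scatter) in this assay, the first step in the series that can be read at this position. The reading therefore holds across an exchange that takes the substituent from methoxy, with 2 heavy atoms and 1 hydrogen-bond acceptor, to nitro, with 3 heavy atoms, 2 hydrogen-bond acceptors and 1 double bond outside aromatic rings. No measurement at hand speaks to why the reading holds across this exchange.

Since compound 2 and compound 3 both read at the top of the scale, this pair sets no lower edge for what the position accepts in this assay, and a larger step may still lie with other groups. Going by these compounds, whether an amine, a carboxylic acid or a longer chain on the same aromatic carbon would bring the reading down remains open, as does whether any change to the shared core away from this ring would do so.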